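The source may report more compounds than this note shows. Statements on the series, on what has been measured and on what is new or still open speak of the compounds shown alone.

Compound 1 has the structure `CN(C)c1ccc(/C=N/NC(=O)CCN2CCN(c3ccnc4cc(Cl)ccc34)CC2)cc1`; in an ADME assay on cells (Splenocyte, Mus musculus, strain BALB/c) for cytotoxicity, read by thymidine incorporation, with a stated time of 24 h (on this read-out lower numbers stand for stronger inhibition and higher numbers for weaker inhibition), compound 1 gives a limit of the assay, > 100000 nM, and no number. Compound 2, `CC(C)c1ccc(/C=N/NC(=O)CCN2CCN(c3ccnc4cc(Cl)ccc34)CC2)cc1`, gives 7900 nM. Compound 3, `O=C(CCN1CCN(c2ccnc3cc(Cl)ccc23)CC1)N/N=C/c1ccc([N+](=O)[O-])cc1`, gives 12100 nM.

Compound 3 holds the highest of the two numbers recorded, but its nearest neighbour, compound 2, sits within the scatter of it a 1.5-fold higher number from compound 2 to compound 3 (0.19 log units; within the scatter). Among the compounds with values here, the only other value, that of compound 1, is a limit.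

Compound 4, `COc1cc(/C=N/NC(=O)CCN2CCN(c3ccnc4cc(Cl)ccc34)CC2)ccc1OC(C)C`, is not yet measured. Its change from compound 3 is 4-isopropoxy-3-methoxyphenyl in place of 4-nitrophenyl on a carbon with a double bond to nitrogen.

Within the data shown here, no measured step exchanges this kind of group. Among the measured compounds shown here, the steps that bear on it are the swaps at the same aromatic position: the move from dimethylamino to nitro an at least 8.2-fold lower number from compound 1 to compound 3 (0.91 log units; beyond the scatter), which was at least modest, and the move from isopropyl to nitro a 1.5-fold higher number from compound 2 to compound 3 (0.19 log units; within the scatter), which stayed within the scatter. Two of the three groups tried gave numbers close to each other, while dimethylamino gave only a limit. A move to an alkoxy-bearing ring is therefore expected to give a step in this assay no larger than modest, and if anything toward a higher number.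

Compound 4 is accordingly estimated at 18000 nM, between 5000 nM and 70000 nM, which means an expected step of a 1.5-fold higher number from compound 3 to compound 4 (0.17 log units; within the scatter).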

Compound 4, half-maximal inhibitory concentration: 8800 nM
Estimate against measurement, compound 4: 2.0-fold (0.31 log units) above, and the stated range covers the measured number.
By their numbers in this assay, from the lowest: compounds 2, 4 and 3 (each within the scatter of the next). At a limit, above all of these: compound 1.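

The exchange of 4-nitrophenyl for 4-isopropoxy-3-methoxyphenyl on a carbon with a double bond to nitrogen gives a 1.4-fold lower number from compound 3 to compound 4 (0.14 log units; within the scatter), and the exchange of 4-isopropylphenyl for the same group gives a 1.1-fold higher number from compound 2 to compound 4 (0.05 log units; within the scatter), so in this assay these three groups cannot be told apart, and a ring carrying two substituents reads like a ring carrying one. Set against 4-(dimethylamino)phenyl, the same group gives an at least 11-fold lower number from compound 1 to compound 4 (1.05 log units; beyond the scatter), which leaves 4-(dimethylamino)phenyl as the only group of the four that stands apart from the rest. The value of compound 1 is a limit and not a number, so the true size of this separation stays unknown: the limit of > 100000 nM in this assay, at which 1 of the 4 values shown sits.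

As far as these compounds go, whether that separation belongs to dimethylamino alone or extends to another amine on the ring, such as a plain amino group or a pyrrolidine, stays open. Also open, from the compounds shown here alone, is whether a carboxylic acid on the ring, or a longer chain within the shared core, would move the number at all.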